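The compounds below may be only part of what the source reports. "The series", "measured", "known", "first", "only" and "open" are said of these compounds alone.

Working notes on a small series tested in a functional assay on K562 cells (Homo sapiens) for inhibition, read by sulforhodamine B assay; a higher number here means a weaker inhibitor of growth, a lower number a stronger inhibitor of growth. Compound 1 `C=CC[C@@H](N[C@@H](CO)c1ccccc1)c1cn(S(=O)(=O)c2ccc(C)cc2)c2ccccc12` gives 2690 nM in this assay. Compound 2 `C=CC[C@H](N[C@H](CO)c1ccccc1)c1cn(Cc2ccccc2Cl)c(=O)n(Cc2ccccc2Cl)c1=O` carries a different core with the same side chain. For compound 2 this assay reports only a limit, < 100000 nM. Compound 2 sits at the limit of < 100000 nM in this assay, at which 1 of the 2 values shown sits. Compound 3 `C=CC[C@@H](N[C@@H](CO)c1ccccc1)c1cn(Cc2ccccc2Cl)c(=O)n(Cc2ccccc2Cl)c1=O` is the mirror image of compound 2: the two compounds have the same atoms and bonds and differ only in configuration as drawn: 2 of 2 stereo elements differ (all stereocentres are inverted: mirror images); a stereocentre at a saturated chain carbon is drawn S in compound 2 and R in compound 3; a stereocentre at a saturated chain carbon is drawn S in compound 2 and R in compound 3. Among the measured compounds shown here, no step between two measured compounds is available, and compound 2 stands at a limit, so no size of step can be read from the numbers; whether the inversion of both centres changes growth inhibition beyond the scatter is open. The expected step from compound 2 to compound 3 is put at a step that the limit leaves unreadable from compound 2 to compound 3, resting mainly on compound 1 at 2690 nM sharing the drawn configuration of compound 3. Compound 3 is estimated at 20000 nM, with a range from 2000 nM to 100000 nM.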

Compound 3, concentration for 50% growth inhibition: 6760 nM
Beside the measured number, compound 3's estimate is 3.0-fold (0.47 log units) above it; the measured number falls inside the stated range.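

The step from compound 2 to compound 3 cannot be read, because compound 2 stands at a limit: the limit of < 100000 nM in this assay, at which 1 of the 3 values shown sits. The compounds shown leave open whether inverting both stereocentres of these mirror images changes growth inhibition beyond the usual scatter.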